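Swapping an Oxazole for a Thiazolylamine on a Shared Core

The compounds below may be only part of what the source reports. "The series", "measured", "known", "first", "only" and "open" are said of these compounds alone.

Measured compounds:
compound 1 `CC(C)C(O)(C(=O)O)c1ccc(-c2ccc3ccccc3c2)[nH]c1=O` 544 nM
compound 2 `CCn1ncc2c(F)cc(-c3ccc(C(CC)(CC)c4nnc[nH]4)c(=O)[nH]3)cc21` 17 nM
compound 3 `CC(C)C(c1ncco1)c1ccc(-c2ccc3cccc(F)c3c2)[nH]c1=O` 24 nM

In an assay on CHO cells for displacement of a labelled ligand from prostaglandin E2 receptor EP3 subtype (Homo sapiens), read by radioligand binding (a lower number here means a stronger inhibitor, a higher number a weaker inhibitor), compound 3 has the second highest of the three numbers. Its value and that of compound 2 lie within the scatter of each other, so no order can be read between them, while compound 1 gives a clearly higher number than compound 3.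

Compound 4 `CC(C)C(Nc1nccs1)c1ccc(-c2ccc3cccc(F)c3c2)[nH]c1=O` has not yet been measured. It differs from compound 3 in one place: (1,3-thiazol-2-yl)amino in place of 1,3-oxazol-2-yl on a saturated chain carbon bound to an aromatic carbon and a saturated chain carbon. Within the data shown here, no measured pair shows this kind of change, so the expectation rests on compound 3 alone. A small step, most likely toward a somewhat higher number, is expected from compound 3 to compound 4 in this assay, namely a 1.5-fold higher number from compound 3 to compound 4 (0.16 log units; within the scatter). For compound 4 the estimated value is 35 nM, within a range from 10 nM to 120 nM.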

Compound 4, inhibition constant: 9.4 nM
The estimate for compound 4 lay 3.7-fold (0.57 log units) above the measured number; the whole stated range lies above it.
By their numbers in this assay, from the lowest: compounds 4, 2 and 3 (each within the scatter of the next, the first and the last beyond it); then compound 1.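

This position on the saturated chain carbon accepts a larger group than 1,3-oxazol-2-yl: in this assay, (1,3-thiazol-2-yl)amino gives a 2.6-fold lower number from compound 3 to compound 4 (0.41 log units; beyond the scatter) and so a modest gain in binding. The entering group also carries a hydrogen-bond donor that the leaving group lacks, yet the number fell rather than rose. Nothing available explains why this swap strengthens binding.

The change alters both the ring and the amino link, and the compounds shown do not separate the two. A 1,3-oxazol-2-ylamino group at this position would change only the ring relative to compound 4.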